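The compounds below may be only part of what the source reports. "The series", "measured", "known", "first", "only" and "open" are said of these compounds alone.

Working notes on the urea series. In a functional assay on Shh Light II cells (Mus musculus) for inhibition, read by a luciferase reporter (on this read-out lower numbers stand for stronger inhibition and higher numbers for weaker inhibition), compound 3 (`O=C(Nc1ccccc1C(F)(F)F)N1CCC(c2nc(-c3ccc4ccccc4n3)no2)CC1`) gives 700 nM. Compound 1 (`O=C(NC1CCS(=O)(=O)CC1)N1CCC(c2nc(-c3ccc4ccccc4n3)no2)CC1`), at 360 nM, lies within the scatter of that value, while compound 2 (`N#Cc1ccccc1NC(=O)N1CCC(c2nc(-c3ccc4ccccc4n3)no2)CC1`), at 190 nM, is separated from it beyond the scatter.

Compound 4 (`O=C(NC1CCOCC1)N1CCC(c2nc(-c3ccc4ccccc4n3)no2)CC1`) has oxan-4-yl in place of 2-(trifluoromethyl)phenyl on an amide-type nitrogen.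

Among the compounds with values here, the closest measured guide is compound 1, the only measured compound with a non-aromatic ring on that nitrogen, and the relevant step is a 1.9-fold higher number from compound 1 to compound 3 (0.29 log units; within the scatter). Within the data shown here, exchanging the aromatic group for the one in compound 2 gives a 1.9-fold lower number from compound 1 to compound 2 (0.28 log units; within the scatter), so neither exchange of this kind leaves the scatter. Among the measured compounds shown here, the one step beyond it, a 3.7-fold higher number from compound 2 to compound 3 (0.57 log units; beyond the scatter), is modest and involves only a substituent on the aromatic ring, which compound 4 lacks. Oxan-4-yl itself has not been measured, so the parallel with compound 1 remains an assumption.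

In this assay, a small move towards a lower number is therefore expected, with no clear change beyond the scatter. The expected change is a 1.8-fold lower number from compound 3 to compound 4 (0.24 log units; within the scatter).

For compound 4 the estimated value is 400 nM, with an expected range of 150 nM to 1000 nM.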

Compound 4, half-maximal inhibitory concentration: 480 nM
Estimate against measurement, compound 4: 1.2-fold (0.08 log units) below, and the stated range covers the measured number.
By their numbers in this assay, from the lowest: compounds 2, 1, 4 and 3 (each within the scatter of the next, the first and the last beyond it).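

In this assay, oxan-4-yl on the amide-type nitrogen gives a 1.5-fold lower number from compound 3 to compound 4 (0.16 log units; within the scatter) and a 1.3-fold higher number from compound 1 to compound 4 (0.12 log units; within the scatter). A second non-aromatic ring therefore lands within the scatter of both earlier neighbours, and the position accepts a ring with a single oxygen as well as the 1,1-dioxothian-4-yl ring of compound 1, with no separation between the two. Within the data shown here, the one step that leaves the scatter is a 2.5-fold higher number from compound 2 to compound 4 (0.40 log units; beyond the scatter), which is modest. Compound 3 also carries an aromatic ring yet stays within the scatter of compound 4. Having an aromatic or a non-aromatic ring at this position does not by itself sort the four values. Nothing available here bears on what lies behind these differences.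

The compounds shown leave open whether a cyclohexyl ring without a hetero atom, a piperidine ring carrying a free amine, a carboxylic acid or an open alkyl chain on this nitrogen would stay in the same range. Going by these compounds, it also remains open whether the separation of compound 2 from compound 4 would hold with a nitrile on another aromatic ring, such as a pyridine.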